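Swapping the aryl group on the hydroxyl-bearing chain carbon

A few compounds are considered here, and "the series" means these few. Any claim that something is new, unique, unknown or untested is made for them only; others in the source may bear on it.

Compound 2 (`COc1ccc(C(O)c2c(C)oc3c([C@H]4CCN(C)C[C@H]4O)c(O)cc(O)c3c2=O)cc1Br`) gives 23% in a functional assay on HL-60 cells (Homo sapiens) for inhibition, read by MTT assay, with a stated time of 48 h, tested at 10 uM (a higher number here means more inhibition of growth at the concentration tested, a lower number less inhibition of growth), and stands level, within the scatter, with compound 1 (`Cc1oc2c([C@H]3CCN(C)C[C@H]3O)c(O)cc(O)c2c(=O)c1C(O)c1cccc(Cl)c1`) at 22% in the same measurement. Compound 3 (`CCOc1ccc(Br)c(C(O)c2c(C)oc3c([C@H]4CCN(C)C[C@H]4O)c(O)cc(O)c3c2=O)c1`) keeps the shared core and differs from compound 2 in one place. There, 2-bromo-5-ethoxyphenyl takes the place of 3-bromo-4-methoxyphenyl on a saturated chain carbon bound to an aromatic carbon and an oxygen on a saturated carbon (2-bromo-5-ethoxyphenyl in place of 3-bromo-4-methoxyphenyl on a saturated chain carbon bound to an aromatic carbon and an oxygen on a saturated carbon). Among the compounds with values here, only one measured step bears on this change. It falls at the same place and exchanges 3-chlorophenyl for 3-bromo-4-methoxyphenyl, giving a number 1 percentage points higher from compound 1 to compound 2 (within the scatter) in that measurement. Within the data shown here, no measured compound carries 2-bromo-5-ethoxyphenyl, so the evidence is thin and the range has to stay wide. No step beyond the scatter is expected in this assay, and the estimated change is a number 1 percentage points higher from compound 2 to compound 3 (within the scatter) at the middle of the estimate. For compound 3 the expected value is 24%, with an estimated range from 10% to 40% for repeated measurements.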

Compound 3, percent growth inhibition at one concentration: 2%
Compound 3: the middle estimate sits 22 percentage points above what was measured; measured number below the stated range.
By their numbers in this assay, from the lowest: compound 3; then compounds 1 and 2 (each within the scatter of the next).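

The saturated chain carbon bound to an aromatic carbon and an oxygen on a saturated carbon is not indifferent to its aryl group in this assay: 2-bromo-5-ethoxyphenyl gives a number 21 percentage points lower from compound 2 to compound 3 (beyond the scatter) and a number 20 percentage points lower from compound 1 to compound 3 (beyond the scatter). Within the data shown here, the one earlier step at this place, a number 1 percentage points higher from compound 1 to compound 2 (within the scatter), showed no response to the aryl group, so that flat reading held only for 3-chlorophenyl and 3-bromo-4-methoxyphenyl and does not extend to every aryl group here. Nothing measured on these compounds accounts for the drop.

Since 2-bromo-5-ethoxyphenyl differs from 3-bromo-4-methoxyphenyl both in the numbering of its substituents and in ethoxy against methoxy, the step cannot be assigned to either difference alone. On these data alone, how a plain phenyl, or an aryl ring bearing an amine or a carboxylic acid, would read at this place stays open, as does whether a longer chain on the ring oxygen would follow compound 3.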